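Changing methoxy to hydroxy on a pyrazole cytotoxicity series

A few compounds are considered here, and "the series" means these few. Any claim that something is new, unique, unknown or untested is made for them only; others in the source may bear on it.

Of the compounds shown here, two with a shared core have been measured in a functional assay on cells (Cancer cell lines, Homo sapiens) for cytotoxicity, read by sulforhodamine B assay, with a stated time of 48 h; a higher number here means a weaker inhibitor of growth, a lower number a stronger inhibitor of growth. Compound 1 `COc1ccc(OC)c(-c2cc(-c3ccc(Cl)cc3)nn2-c2ccccc2)c1` gives 34900 nM in this assay. Compound 2 `COc1ccc(OC)c(-c2cc(-c3ccc(Cl)cc3)nn2-c2ccc(S(=O)(=O)NC(C)=O)cc2)c1` carries an acetylsulfamoyl group where compound 1 has only a hydrogen. In this assay compound 2 gives 17700 nM. For the measured compounds named here, the one step recorded, a 2.0-fold lower number from compound 1 to compound 2 (0.29 log units; within the scatter), sits within the scatter, so the two values cannot be told apart; compound 2 stands beside compound 1 rather than apart from it.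

Compound 3 `CC(=O)NS(=O)(=O)c1ccc(-n2nc(-c3ccc(Cl)cc3)cc2-c2cc(O)ccc2O)cc1` is not yet measured. It differs from compound 2 in one place: 2,5-dihydroxyphenyl in place of 2,5-dimethoxyphenyl on an aromatic carbon. Going by the values given here, no measured step touches this change; the only recorded step, from compound 1 to compound 2, concerns the acetylsulfamoyl group and says nothing about the methoxy-to-hydroxy exchange. With no guide in the data, the expectation for compound 3 is a number close to that of compound 2, with the step of a 1.3-fold lower number from compound 2 to compound 3 (0.10 log units; within the scatter) expected to fall within the scatter. The estimate for compound 3 in this assay is therefore 14000 nM, with a range from 4000 nM to 45000 nM.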

Compound 3, concentration for 50% growth inhibition: 23500 nM
For compound 3 the middle estimate is 1.7-fold (0.22 log units) below the measured one; the range from low to high includes it.
By their numbers in this assay, from the lowest: compounds 2, 3 and 1 (each within the scatter of the next).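

In this assay, replacing 2,5-dimethoxyphenyl with 2,5-dihydroxyphenyl on the aromatic carbon next to the ring nitrogen gives a 1.3-fold higher number from compound 2 to compound 3 (0.12 log units; within the scatter), so compound 2 and compound 3 cannot be told apart. For the compounds shown here, this is the first measured change at this position, and it shows that, with the acetylsulfamoyl group in place, a smaller group carrying hydrogen-bond donors that the dimethoxy group lacks can stand here without a difference that this measurement can resolve; that finding rests on this single pair and does not extend to other groups at this position. Nothing available explains this result or shows what the two groups do in the cells.

The compounds shown leave open whether the same exchange would also make no measurable difference on compound 1, which has a hydrogen in place of the acetylsulfamoyl group, and whether each hydroxy group matters alone. They also leave open whether an amine, a carboxylic acid or a longer chain such as ethoxy on this phenyl ring would give a number that stands clearly apart from those of compound 2 and compound 3.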